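This account rests on a few compounds, and the source may have more. Where it says the series, first, only, none or still open, it means among the compounds named here.

Measured so far in an ADME assay on liver for metabolic stability, with Liver microsome (Homo sapiens) as the target, using microsomes (on this read-out higher numbers stand for fast clearance and lower numbers for slow clearance), are:
- compound 1 `N#Cc1ccc(C2CCN(C(=O)Nc3cc(-c4ccccn4)n[nH]3)CC2)cc1` with 25.3 mL.min-1.g-1
- compound 2 `N#Cc1ccc(OC2CCN(C(=O)Nc3cc(-c4ccccn4)n[nH]3)CC2)cc1` with 14.7 mL.min-1.g-1

Compound 2 sits within the scatter of compound 1 and holds no separate place of its own. Compound 3 `O=C(Nc1cc(-c2ccccn2)n[nH]1)N1CCC(c2ccc(F)cc2)CC1` brings a further change at that same saturated ring carbon: 4-fluorophenyl in place of 4-cyanophenoxy on a saturated ring carbon. Among the compounds with values here, since the one measured step there (a 1.7-fold lower number from compound 1 to compound 2 (0.24 log units; within the scatter)) stayed within the scatter, no step beyond it is expected in this assay for compound 3. The expected move is a 1.7-fold higher number from compound 2 to compound 3 (0.23 log units; within the scatter) and would remain within that scatter. Compound 3 is estimated at 25 mL.min-1.g-1 (10 mL.min-1.g-1 to 60 mL.min-1.g-1).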

Compound 3, intrinsic clearance in microsomes: 42.5 mL.min-1.g-1
Compound 3: middle estimate off by 1.7-fold (0.23 log units), on the low side, and the stated range covers the measured number.
By their numbers in this assay, from the lowest: compounds 2, 1 and 3 (each within the scatter of the next, the first and the last beyond it).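

In this assay, the swap at this saturated ring carbon now yields a step beyond the scatter, with 4-fluorophenyl in place of 4-cyanophenoxy giving a 2.9-fold higher number from compound 2 to compound 3 (0.46 log units; beyond the scatter). Fluoro in place of cyano on an aromatic carbon gives only a 1.7-fold higher number from compound 1 to compound 3 (0.23 log units; within the scatter), which leaves compound 1 and compound 3 unseparated. No evidence here bears on the reason for either step.

On these data alone, whether the oxygen link would keep its place with fluoro in place of cyano remains open. So does how a methoxy group or an amine at that aromatic carbon would read in this assay, since only nitrile and fluoro appear there.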